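A few compounds are considered here, and "the series" means these few. Any claim that something is new, unique, unknown or untested is made for them only; others in the source may bear on it.

For the measured compounds named here, in a physicochemical assay for solubility, read by HPLC, in phosphate buffer, measured as kinetic solubility, at pH 7.4 (a higher number here means a more soluble compound, a lower number a less soluble compound), compound 1 (`CCC(=O)c1ccn(-c2ccc(S(N)(=O)=O)cc2)c1C`) gives 100000 nM, the higher of the two numbers measured so far. Going by the values given here, the only other measured compound, compound 2 (`CCOC(=O)c1cc(-c2ccc(Cl)cc2)n(-c2ccc3cc[nH]c3c2)c1C`), gives 5100 nM, a lower number by a margin beyond the usual scatter. Compound 3 (`CCC(=O)c1cc(-c2ccccc2)n(-c2ccc(S(N)(=O)=O)cc2)c1C`) has not yet been measured. It differs from compound 1 in one place: phenyl in place of hydrogen on an aromatic carbon, next to the ring nitrogen and next to the ring atom that bears a large group. Among the compounds with values here, no step between measured compounds is available to size this change, so the expectation rests on the two values alone. Differing from compound 1 elsewhere too, and also carrying a phenyl group, though a chlorinated one, compound 2 stands at 5100 nM. A fall in this assay beyond the scatter is therefore expected, though a smaller one than the gap between those two numbers. The expected step is a 4.0-fold lower number from compound 1 to compound 3 (0.60 log units; beyond the scatter). For compound 3 the estimated value is 25000 nM, with an expected range from 8000 nM to 70000 nM.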

Compound 3, solubility: 14100 nM
For compound 3 the middle estimate is 1.8-fold (0.25 log units) above the measured one; the measured number falls inside the stated range.
By their numbers in this assay, from the lowest: compound 2; then compound 3; then compound 1.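

In this assay, for the compounds shown here, the exchange of hydrogen for phenyl gives a 7.1-fold lower number from compound 1 to compound 3 (0.85 log units; beyond the scatter) and so supplies the first step that sizes one change on its own. It shows that, on this aromatic carbon next to the ring nitrogen and next to the ring atom that bears a large group, phenyl lowers the number beyond the scatter, while compound 3 still reads 14100 nM with the rest of the structure of compound 1 unchanged. No measurement at hand accounts for the size of this step, so its cause stays unassigned.

This single step cannot separate an effect of phenyl itself from what any other group would do on the same carbon, so a morpholine ring, a carboxylic acid or a short amine chain there could give a smaller step, a larger one or none at all. It also leaves open whether phenyl would lower the number by a similar amount on the other ring carbon that carries hydrogen in compound 1, or with the propanoyl group replaced by an ethyl ester.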